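A few compounds are considered here, and "the series" means these few. Any claim that something is new, unique, unknown or untested is made for them only; others in the source may bear on it.

Of the compounds shown here, two with the same core have been measured so far. In a functional assay on SN12C cells (Homo sapiens) for inhibition (a higher number here means a weaker inhibitor of growth, a lower number a stronger inhibitor of growth), compound 1 (`COc1ccc(-n2cnnc2-c2cc(OC)c(OC)c(OC)c2)cc1`) gives 4070 nM, the higher of the two numbers, which makes it the weaker growth inhibitor of the pair. Compound 2 (`COc1cc(-c2nncn2-c2ccc(N(C)C)cc2)cc(OC)c1OC`) gives 724 nM.

The next compound, compound 3 (`COc1ccc(-n2cnnc2-c2cc(OC)c(OC)c(OC)c2)cc1O`), keeps all of compound 1 and makes one change: hydroxy in place of hydrogen on an aromatic carbon. This is hydroxy in place of hydrogen on an aromatic carbon, ortho to a methoxy group and meta to a large group.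

Among the measured compounds shown here, only one measured step bears on this change. It is a 5.6-fold lower number from compound 1 to compound 2 (0.75 log units; beyond the scatter), and it alters the same ring. For the measured compounds named here, that step swaps one group for another rather than filling a hydrogen position, and no measured compound carries a hydroxy, so it is only a loose guide. It does show that this ring can shift the number beyond the scatter, so a modest move towards a lower number is expected, with much uncertainty.

The expected change is an 8.1-fold lower number from compound 1 to compound 3 (0.91 log units; beyond the scatter). For compound 3 the estimated value is 500 nM, with a range of 50 nM to 3500 nM.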

Compound 3, concentration for 50% growth inhibition: 603 nM
The estimate for compound 3 lay 1.2-fold (0.08 log units) below the measured number; the measured number falls inside the stated range.
By their numbers in this assay, from the lowest: compounds 3 and 2 (each within the scatter of the next); then compound 1.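

In this assay, hydroxy in place of hydrogen on an aromatic carbon, ortho to a methoxy group and meta to a large group, gives a 6.7-fold lower number from compound 1 to compound 3 (0.83 log units; beyond the scatter). The earlier step, a 5.6-fold lower number from compound 1 to compound 2 (0.75 log units; beyond the scatter), replaced one group with another, whereas this one fills a hydrogen position and leaves the methoxy group of compound 1 in place, so the number on this ring can also move beyond the scatter through an added group. The addition is only one heavy atom, an oxygen, so on this carbon even a very small change is enough to shift the number this far, although no measurement shown explains the shift.

Still open is whether the effect belongs to hydroxy in particular, since the same carbon has been shown carrying only hydrogen or hydroxy, and a methoxy group, an amine or a fluorine atom there could give a quite different number. Also open, as far as these compounds go, is whether hydroxy at this carbon would lower the number again when combined with the dimethylamino group of compound 2, or whether the two changes would add nothing to each other.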